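Naphthyridinone amides: ring swap with no starting value

A few compounds are considered here, and "the series" means these few. Any claim that something is new, unique, unknown or untested is made for them only; others in the source may bear on it.

Measured compounds
compound 1, `O=C(Nc1ccc(Oc2ccnc3[nH]ccc23)cc1)c1cc2cccnc2n(-c2ccccc2)c1=O`: 380 nM
compound 2, `O=C(Nc1ccc(Oc2ccnc3[nH]ccc23)cc1)c1cc2cccnc2n(-c2ccc(F)c(Cl)c2)c1=O`: "not determined" (no result reported)

Compound 1 carries a plain phenyl on the aromatic nitrogen of the shared core and in a functional assay on NCI-H460 cells (Homo sapiens) for antiproliferative activity, read by MTT assay, with a stated time of 72 h (on this read-out higher numbers stand for weaker inhibition and lower numbers for stronger inhibition), compound 1 gives 380 nM. Compound 2 differs from it by a 3-chloro-4-fluorophenyl in the same place, yet for compound 2 the outcome in this assay is recorded as "not determined" (no result reported), so compound 2 stands on no number at all and offers no anchor of its own.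

Compound 3, `O=C(Nc1ccc(Oc2ccnc3[nH]ccc23)cc1)c1cc2cccnc2n(-c2ccc(C(F)(F)F)cc2Cl)c1=O`, is the next member and has not been measured. Its change from compound 2 is 2-chloro-4-(trifluoromethyl)phenyl in place of 3-chloro-4-fluorophenyl on an aromatic nitrogen. Among the measured compounds shown here, with no value for compound 2 and no measured step between any two compounds, there is nothing to say about the direction or the size of this step in this assay beyond the single point given by compound 1. For the measured compounds named here, the only reference is compound 1 with its 380 nM.

On that basis compound 3 is expected to land near compound 1, with an estimated 400 nM in this assay and a wide range from 100 nM to 1600 nM.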

Compound 3, half-maximal inhibitory concentration: 1950 nM
Compound 3: the middle estimate sits 4.9-fold (0.69 log units) below what was measured, outside the stated range (above it).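

In this assay, putting 2-chloro-4-(trifluoromethyl)phenyl in place of phenyl on the aromatic nitrogen gives a 5.1-fold higher number from compound 1 to compound 3 (0.71 log units; beyond the scatter). Among the compounds shown here, this is the first measured step at this position, and it shows that the read-out responds to a change here, moving toward weaker inhibition by more than the usual scatter. Compound 2 has no number, so the step from it to compound 3 cannot be read, and nothing in the data accounts for the rise.

For the compounds shown here, compound 3 differs from compound 1 by chlorine and trifluoromethyl together, so the single step cannot show how much of the shift belongs to either substituent, and a phenyl carrying only one of them would be needed to separate the two. From the compounds shown here alone, it also remains open whether a smaller substituent such as methoxy, or an amine or a carboxylic acid on the phenyl, would stay closer to compound 1 or move the number in the other direction.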